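The source may report more compounds than this note shows. Statements on the series, on what has been measured and on what is new or still open speak of the compounds shown alone.

Measured so far in a functional assay on SR cells (Homo sapiens) for inhibition, read by sulforhodamine B assay, with a stated time of 48 h, tested at 10 uM; on this read-out higher numbers stand for more inhibition at the one concentration tested (going by the name of the read-out) and lower numbers for less inhibition:
compound 1 `c1ccc2c(-c3cn4ccnc4c(-c4ccc5ncn(C6CCCCC6)c5c4)n3)cccc2c1` gives 6.92%
compound 2 `COc1ccccc1-c1cn2ccnc2c(-c2ccc3ncn(C4CCCCC4)c3c2)n1` gives 26.3%

For the measured compounds named here, compound 2 stands highest of the two numbers; the one step available, a number 19.4 percentage points higher from compound 1 to compound 2 (beyond the scatter), lies beyond the scatter and is modest in size. Compound 3 `FC(F)(F)c1cccc(-c2cn3ccnc3c(-c3ccc4ncn(C5CCCCC5)c4c3)n2)c1` differs from compound 2 as follows: 3-(trifluoromethyl)phenyl in place of 2-methoxyphenyl on an aromatic carbon. Going by the values given here, no measured step bears directly on this change; the only step at that position, a number 19.4 percentage points higher from compound 1 to compound 2 (beyond the scatter), shows merely that swapping the aryl group there can shift the number modestly. Among the compounds with values here, with no closer precedent, the step of a number 4.3 percentage points lower from compound 2 to compound 3 (within the scatter) is expected to stay within the scatter, with wide uncertainty. Compound 3 is estimated at 22%, in the range 2% to 45%.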

Compound 3, a percentage reported as inhibition, at one concentration (the size of the read-out at that concentration, not a potency): 15.6%
Beside the measured number, compound 3's estimate is 6.4 percentage points above it, within the range that was stated.
By their numbers in this assay, from the lowest: compounds 1 and 3 (each within the scatter of the next); then compound 2.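

In this assay, the swap of 2-methoxyphenyl for 3-(trifluoromethyl)phenyl gives a number 10.7 percentage points lower from compound 2 to compound 3 (beyond the scatter) and so shows that this position responds to a change between two substituted phenyl groups, not only to the loss of naphthalen-1-yl. The swap of naphthalen-1-yl for 3-(trifluoromethyl)phenyl gives a number 8.7 percentage points higher from compound 1 to compound 3 (within the scatter) and so shows that a phenyl group at this position does not by itself separate from naphthalen-1-yl.

Open, going by these compounds, is how a phenyl group carrying an amine or a carboxylic acid would read at this position. No measured evidence bears on the origin of these differences.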